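Ring swap at the chain carbon: solubility outlook

The compounds below may be only part of what the source reports. "The series", "measured", "known", "first", "only" and "open" are said of these compounds alone.

Measured so far in a physicochemical assay for solubility; on this read-out lower numbers stand for lower solubility and higher numbers for higher solubility:
Compound 1 `CNC(=O)c1cc(C(=O)NC2CC2)cn(CC2CCCOC2)c1=O` returns only a limit, >= 131 ug/mL.
Compound 2 `CNC(=O)c1cc(C(=O)NC2CC2)cn(Cc2cccc3cc[nH]c23)c1=O` also returns only a limit, >= 144 ug/mL.
Compound 3 `CNC(=O)c1cc(C(=O)NC2CC2)cn(Cc2nccc3[nH]ccc23)c1=O` returns 73 ug/mL.

Going by the values given here, compound 3 holds the only number in the set; the other two values are limits. The step of an at least 1.7-fold lower number from compound 1 to compound 3 (0.25 log units; that floor lies within the scatter) and the step of an at least 1.9-fold lower number from compound 2 to compound 3 (0.29 log units; that floor lies within the scatter) both run downward to compound 3, though each floor lies within the scatter. The step that the two limits leave unreadable from compound 1 to compound 2 cannot be read, as both ends are limits.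

Compound 4 `CNC(=O)c1cc(C(=O)NC2CC2)cn(Cc2cccc(F)c2)c1=O` is the next member. The change: a group of 7 heavy atoms (6 carbon, 1 fluorine; one six-membered aromatic ring of carbon only) in place of a group of 9 heavy atoms (7 carbon, 2 nitrogen; one five-membered aromatic ring with 1 hetero atom, one six-membered aromatic ring with 1 hetero atom), on a saturated chain carbon bound to an aromatic nitrogen. Among the compounds with values here, no measured step exchanges the group of 9 heavy atoms (7 carbon, 2 nitrogen) for a single six-membered aromatic ring of carbon only, so the nearest guide is compound 2, whose group contains a six-membered aromatic ring of carbon only and which sits at a limit, while compound 3 with its group of 9 heavy atoms (7 carbon, 2 nitrogen) sits at a number. That pairing points to a move upward from compound 3 in this assay, of a size the limits leave uncertain. Compound 4 is expected at 120 ug/mL (range 60 ug/mL to 250 ug/mL), an expected step of a 1.6-fold higher number from compound 3 to compound 4 (0.22 log units; within the scatter), with a fair chance that only a limit is reported.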

Compound 4, solubility: >= 133 ug/mL
Compound 4 was reported as a limit; the forecaster's own chance of this, stated with the estimate: 45%; at least 1.1-fold (0.04 log units) between middle value and limit.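

In this assay, 3-fluorophenyl in place of the two-ring group of compound 3, on a saturated chain carbon bound to an aromatic nitrogen, gives an at least 1.8-fold higher number from compound 3 to compound 4 (0.26 log units; that floor lies within the scatter) and so extends the comparison at this place to a single six-membered aromatic ring of carbon only, with 7 heavy atoms and 0 hydrogen-bond donors. Compound 4 returns only a limit, not a number: the limit of >= 133 ug/mL in this assay, at which 1 of the 4 values shown sits. Oxan-3-yl, 1H-indol-7-yl and now 3-fluorophenyl all end in limits, leaving the two-ring group of compound 3 as the only group shown here with a number, though the floors of its steps to compound 1, compound 2 and compound 4 all lie within the scatter.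

Going by these compounds, the steps among compound 1, compound 2 and compound 4 cannot be read, as both ends of each are limits, so these three groups cannot be ordered and the true size of their gaps to compound 3 stays unknown. Also open, on these data alone, is where a morpholine, a carboxylic acid on the phenyl ring or a longer chain in place of the saturated chain carbon would fall in this assay relative to these values.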